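The compounds below may be only part of what the source reports. "The series", "measured", "known", "first", "only" and "open" are said of these compounds alone.

Measured compounds:
compound 1, `NC(=O)C[C@H](NC(=O)CN(c1nc(Cl)nc2[nH]cnc12)C1CC1)C(=O)O` — 20.1%
compound 2, `NC(=O)C[C@H](NC(=O)CN(c1ncnc2c1ncn2C1CCCCO1)C1CC1)C(=O)OCc1ccccc1` — 35%

In a functional assay on the whole organism (Tail, strain ICR) with Mus musculus as the target, in the tail flick test, with a stated time of 90 min, at a dose of 25 umol/kg by the oral route (on this read-out higher numbers stand for a stronger effect at the one dose given and lower numbers for a weaker effect), compound 1 gives 20.1% and compound 2 gives 35%. Compound 1 stands lowest of the two numbers; the nearest, compound 2, lies higher by a margin beyond the scatter. Going by the values given here, the two differ in more than one place, so no single step between them can be read, and their values are taken only as they stand.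

Compound 3, `CSCC[C@H](NC(=O)CN(c1nc(Cl)nc2[nH]cnc12)C1CC1)C(=O)O`, is not yet measured in this assay. It differs from compound 1 in one place: (methylsulfanyl)methyl in place of carbamoyl on a saturated chain carbon, two bonds along the chain from an amide-type nitrogen and a carbonyl carbon. The shared core and the rest of the chain are unchanged.

Among the compounds with values here, no step between measured compounds resembles this exchange, so there is nothing to set its size. The expectation for the step of a number 3.9 percentage points higher from compound 1 to compound 3 (within the scatter) is therefore one of no movement beyond the scatter, in either direction. On that basis compound 3 is estimated at 24% in this assay, with a range from 8% to 45%.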

Compound 3, a percentage reported as activity, at one dose (the size of the read-out at that dose, not a potency): 14%
Beside the measured number, compound 3's estimate is 10 percentage points above it; the measured number falls inside the stated range.
By their numbers in this assay, from the lowest: compounds 3 and 1 (each within the scatter of the next); then compound 2.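

In this assay, going by these compounds alone, placing (methylsulfanyl)methyl in place of carbamoyl on a saturated chain carbon, two bonds along the chain from an amide-type nitrogen and a carbonyl carbon, gives a number 6.1 percentage points lower from compound 1 to compound 3 (within the scatter), the first step that can be read at a single place. The exchange removes one hydrogen-bond donor and brings in none, while one hydrogen-bond acceptor leaves and one enters, and sulfur replaces the nitrogen and oxygen of the carbamoyl group; even so, at this one dose and time the two numbers stay within the scatter of each other. Nothing available here accounts for this result.

From the compounds shown here alone, whether an amine, a carboxylic acid or a longer chain at this position would move the read-out beyond the scatter remains open. Going by these compounds, it is also open whether the same exchange would read the same way on the structure of compound 2, which carries a benzyl ester and a tetrahydropyran-bearing core, or at other doses and times.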